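Compound 4: carboxymethyl on the amide-type nitrogen

The source may report more compounds than this note shows. Statements on the series, on what has been measured and on what is new or still open speak of the compounds shown alone.

The compounds here share one core and differ on an amide-type nitrogen, and all are read in a functional assay on MCF7 cells (Homo sapiens) for antiproliferative activity, read by MTT assay, with a stated time of 24 h (a higher number here means a weaker inhibitor, a lower number a stronger inhibitor), as the measure of their effect. Compound 1 (`CCn1c(C(=O)NCCNC(=O)OC(C)(C)C)ccc1C(CC)(CC)c1ccc(OCS(=O)(=O)c2ccccc2)c(C)c1`) gives > 50000 nM here, which is a limit and not a number. Among the measured compounds shown here, compound 2 (`CCn1c(C(=O)NC2(CO)CC2)ccc1C(CC)(CC)c1ccc(OCS(=O)(=O)c2ccccc2)c(C)c1`) gives 28800 nM and compound 3 (`CCn1c(C(=O)N[C@@H](CO)C(C)C)ccc1C(CC)(CC)c1ccc(OCS(=O)(=O)c2ccccc2)c(C)c1`) gives 18800 nM as the only two numerical readings, and these stand within the scatter of each other (a 1.5-fold lower number from compound 2 to compound 3 (0.19 log units; within the scatter)). Compound 3 therefore sits level with compound 2.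

Compound 4 (`CCn1c(C(=O)NCC(=O)O)ccc1C(CC)(CC)c1ccc(OCS(=O)(=O)c2ccccc2)c(C)c1`) carries carboxymethyl in place of 1-(hydroxymethyl)-2-methylpropyl on an amide-type nitrogen. For the measured compounds named here, no measured compound carries carboxymethyl, so the measured steps bear on this change only indirectly. The step to compound 2 (an at least 1.7-fold lower number from compound 1 to compound 2 (0.23 log units; that floor lies within the scatter)) has a floor within the scatter, while the step to compound 3 (an at least 2.6-fold lower number from compound 1 to compound 3 (0.42 log units; beyond the scatter)) has a floor beyond it. Compound 4 loses the hydroxymethyl group, and compound 1 also lacks one, with its reading at the limit (> 50000 nM). A modest step towards a higher number is therefore expected, and a reading at the limit would be no surprise. The expected change is a 2.0-fold higher number from compound 3 to compound 4 (0.31 log units; beyond the scatter) in this assay on this estimate. Compound 4 is estimated at 38000 nM with an expected range from 17000 nM to 60000 nM overall.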

Compound 4, half-maximal inhibitory concentration: 33100 nM
Beside the measured number, compound 4's estimate is 1.1-fold (0.06 log units) above it; low and high end bracket the measured number.
By their numbers in this assay, from the lowest: compounds 3, 2 and 4 (each within the scatter of the next). At a limit, above all of these: compound 1.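

With carboxymethyl on the amide-type nitrogen, compound 4 shows that a group without hydroxymethyl can still give a numerical reading in this assay, and that reading cannot be separated from those of the two hydroxymethyl-bearing compounds: a 1.8-fold higher number from compound 3 to compound 4 (0.25 log units; within the scatter) and a 1.1-fold higher number from compound 2 to compound 4 (0.06 log units; within the scatter). Among the compounds shown here, compound 4 cannot be separated from compound 1 on the printed floor either, with an at least 1.5-fold lower number from compound 1 to compound 4 (0.17 log units; that floor lies within the scatter), so the only step in this set that lies beyond the scatter remains the one from compound 1 to compound 3. On these data alone, compound 1, which also lacks hydroxymethyl, stands at a limit and not at a number, so the true size of its steps stays unknown: the limit of > 50000 nM in this assay, at which 1 of the 4 values shown sits.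

Compounds 2, 3 and 4 lie within the scatter of one another, so these readings do not rank the three groups on this nitrogen or show that any one of them matters more than another. As far as these compounds go, it remains open whether a free amine on a two-carbon chain, a methyl ester in place of the carboxylic acid, or a longer chain ending in the acid would move the number beyond that scatter.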